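A few compounds are considered here, and "the series" means these few. Any claim that something is new, unique, unknown or untested is made for them only; others in the source may bear on it.

In a functional assay on MDA-MB-231 cells (Homo sapiens) for cytotoxicity, read by MTT assay, with a stated time of 48 h (a higher number here means a weaker inhibitor, a lower number a stronger inhibitor), compound 1 `C=C1CC[C@@H]2[C@](C)(CO)[C@H](O)CC[C@@]2(C)[C@@H]1CCc1ccoc1` gives > 100000 nM, which is a limit of the assay and not a number. Compound 2 `C=C1CC[C@@H]2[C@](C)(COC(=O)c3ccc([N+](=O)[O-])cc3)[C@H](OC(=O)c3ccc([N+](=O)[O-])cc3)CC[C@@]2(C)[C@@H]1CCc1ccoc1` gives > 100000 nM, likewise a limit. The evidence so far is the limit of > 100000 nM in this assay, at which 2 of the 2 values shown sit, so compound 1 offers no number to step from. Compound 3 `C=C1CC[C@@H]2[C@](C)(COC(=O)c3ccc(OC)cc3)[C@H](O)CC[C@@]2(C)[C@@H]1CCc1ccoc1` differs from compound 1 by one change: (4-methoxyphenyl)carbonyl in place of hydrogen on an oxygen on a saturated carbon, which reads as hydroxy to ((4-methoxyphenyl)carbonyl)oxy. With both measured compounds reported only as limits, a small gain in inhibition at most is expected, and another limit reading remains likely. The estimated step is an at least 1.6-fold lower number from compound 1 to compound 3 (0.22 log units; that floor lies within the scatter). Compound 3 is estimated at 60000 nM, with an expected range of 15000 nM to 150000 nM.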

Compound 3, half-maximal inhibitory concentration: 28600 nM
The estimate for compound 3 lay 2.1-fold (0.32 log units) above the measured number; measured number inside the range.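

In this assay, placing (4-methoxyphenyl)carbonyl on this oxygen on a saturated carbon gives an at least 3.4-fold lower number from compound 1 to compound 3 (0.54 log units; beyond the scatter). As far as these compounds go, compound 1 gives > 100000 nM, which is a limit and not a number, so the step is a floor and its true size stays open. Compound 3 is the only compound shown with a measured number rather than a limit: the limit of > 100000 nM in this assay, at which 2 of the 3 values shown sit.

From the compounds shown here alone, whether the gain needs the methoxy or only the aromatic ring stays open. Also open, going by these compounds, is how an amine or a longer alkyl chain would read at this oxygen.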